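The source may hold more compounds than are shown below. What is called first, only, known or untested is meant among the compounds shown, and "the series" means these compounds.

Measured compounds:
compound 1, `CC(C)(C)C1=NN(c2cccc(Cl)c2)C(c2ccc(O)cc2)C1`: 96.8%
compound 2, `Cc1cccc(N2N=C(C(C)(C)C)CC2c2ccc(O)cc2)c1`: 91.7%
compound 3, `CC(C)(C)C1=NN(c2ccccc2Cl)C(c2ccc(O)cc2)C1`: 57.1%

All three were read in an assay on isolated protein for inhibition of protein kinase C zeta type (Homo sapiens), with a stated time of 4 min, tested at 62.5 uM; a lower number here means less inhibition, a higher number more inhibition at the concentration tested (going by the name of the read-out). Compound 1 and compound 2 sit close together, a number 5.1 percentage points lower from compound 1 to compound 2 (within the scatter), so no order is drawn between them. Compound 3 stands lowest of the three numbers; its nearest neighbour is compound 2, a number 34.6 percentage points lower from compound 2 to compound 3 (beyond the scatter), and its furthest is compound 1, a number 39.7 percentage points lower from compound 1 to compound 3 (beyond the scatter), both beyond the scatter.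

Compound 4, `CC(C)(C)C1=NN(c2ccc(F)cc2F)C(c2ccc(O)cc2)C1`, is not yet measured. The change from compound 3 is 2,4-difluorophenyl in place of 2-chlorophenyl on an amine nitrogen in a ring. The two steps that bear on it are those into compound 3, a number 39.7 percentage points lower from compound 1 to compound 3 (beyond the scatter) and a number 34.6 percentage points lower from compound 2 to compound 3 (beyond the scatter), where 2-chlorophenyl replaced 3-chlorophenyl or 3-methylphenyl with a large loss. Compound 4 carries 2,4-difluorophenyl and not 3-chlorophenyl or 3-methylphenyl, so no return toward compound 1 or compound 2 is expected; nothing in the measured set separates 2-chlorophenyl from 2,4-difluorophenyl directly. For compound 4 the expected step is therefore a number 5.9 percentage points higher from compound 3 to compound 4 (within the scatter), within the scatter. Compound 4 is estimated at 63%, range 42% to 84%.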

Compound 4, a percentage reported as inhibition, at one concentration (the size of the read-out at that concentration, not a potency): 68%
Compound 4: middle estimate off by 5 percentage points, on the low side; low and high end bracket the measured number.
By their numbers in this assay, from the lowest: compound 3; then compound 4; then compounds 2 and 1 (each within the scatter of the next).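

In this assay the group on the amine nitrogen in the ring can now be read away from 2-chlorophenyl without returning to 3-chlorophenyl or 3-methylphenyl: 2,4-difluorophenyl in place of 2-chlorophenyl gives a gain beyond the scatter (a number 10.9 percentage points higher from compound 3 to compound 4 (beyond the scatter)). The gain recovers only part of the earlier loss, since the steps from the other two groups remain downward (a number 23.7 percentage points lower from compound 2 to compound 4 (beyond the scatter) and a number 28.8 percentage points lower from compound 1 to compound 4 (beyond the scatter)), which places 2,4-difluorophenyl on the numbers between 2-chlorophenyl and the pair 3-chlorophenyl and 3-methylphenyl, so this position separates three levels among four aryl groups. No measurement in hand accounts for these differences.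

The step to compound 4 exchanges chlorine for fluorine and adds a second fluorine in one change, and 2-fluorophenyl and 4-fluorophenyl groups would be needed to assign it to either part. Also open, from the compounds shown here alone, are how a 3-methoxyphenyl group or a phenyl carrying a carboxylic acid would read at this nitrogen, and whether the order of the aryl groups holds with another group in place of the tert-butyl group or the 4-hydroxyphenyl group.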